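The source may hold more compounds than are shown below. What is called first, only, known or untested is meant among the compounds shown, and "the series" means these compounds.

Measured compounds:
- compound 1 `CC(=O)OC/C(=C\c1ccc(Cl)cc1Cl)C(=O)c1ccccc1`: 8700 nM
- compound 2 `COc1ccc(C(=O)/C(=C/c2ccccc2F)COC(C)=O)cc1`: 30000 nM
- compound 3 `COc1ccc(C(=O)/C(=C/c2ccc(Cl)cc2Cl)CCOC(C)=O)cc1`: 83400 nM

In a functional assay on MCF7 cells (Homo sapiens) for inhibition, read by XTT assay, with a stated time of 48 h (on this read-out higher numbers stand for weaker inhibition and lower numbers for stronger inhibition), compound 3 gives 83400 nM, the highest number of the three, so it is the weakest inhibitor of the set. The gap between compound 3 and compound 2 is beyond the usual scatter. The gap between compound 3 and compound 1 is larger still. Within the data shown here, compound 1 and compound 2 each differ from compound 3 in more than one place, so their values set only the range seen and give no single-change step.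

Compound 4 `COc1ccc(C(=O)/C(=C/c2ccc([N+](=O)[O-])cc2)CCOC(C)=O)cc1` is the next compound and is not yet measured in this assay. It differs from compound 3 in one place: 4-nitrophenyl in place of 2,4-dichlorophenyl on a double-bonded chain carbon bound to a double-bonded chain carbon. Among the measured compounds shown here, no measured pair shows this change, and nothing in the numbers says which way it should go. The expected step from compound 3 to compound 4 is therefore a 1.4-fold lower number from compound 3 to compound 4 (0.14 log units; within the scatter), not beyond the scatter in either direction, with a wide margin of doubt. For compound 4 in this assay the estimate is 60000 nM, ranging from 15000 nM to 200000 nM.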

Compound 4, half-maximal inhibitory concentration: > 100000 nM
Compound 4: a limit, no number; the forecaster's own chance of this, stated with the estimate: 25%; at least 1.6-fold (0.22 log units) between middle value and limit.
By their numbers in this assay, from the lowest: compound 1; then compound 2; then compound 3. At a limit, above all of these: compound 4.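

In this assay compound 4 gives > 100000 nM, which is a limit and not a number. Among these compounds, the first single-change step, 4-nitrophenyl in place of 2,4-dichlorophenyl on a double-bonded chain carbon bound to a double-bonded chain carbon, reads as an at least 1.1-fold higher number from compound 3 to compound 4 (0.07 log units; that floor lies within the scatter), so at this position the change brings no lower number on this read-out, and compound 3 remains the only compound of this pair with a measured number. The step has only a floor, and its full size cannot be read from a limit: the limit of > 100000 nM in this assay, at which 1 of the 4 values shown sits.

Still open, from the compounds shown here alone, is whether any group at this place would bring the number down from that of compound 3, and plain phenyl, an aminophenyl or a carboxyphenyl group would test this on the same core. Also open, going by these compounds, is whether the swap from 2,4-dichlorophenyl to 4-nitrophenyl would run the same way on the core of compound 1, whose number is the lowest, since a single pair on one core gives no trend for the series as a whole.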